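The source may report more compounds than this note shows. Statements on the series, on what has been measured and on what is new or still open speak of the compounds shown alone.

Measured in a functional assay on the whole organism (stomach) with Rattus norvegicus as the target; a higher number here means that more compound is needed for the effect, a lower number that less compound is needed:
- compound 1 `CCCCCC/N=C/N1CCC(C(c2ccccc2)c2ccccc2)CC1`: 15 mg/kg
- compound 2 `C=CC/N=C/N1CCC(C(c2ccccc2)c2ccccc2)CC1`: 13.2 mg/kg

For the measured compounds named here, compound 2 lies within the scatter of compound 1, the only other measured compound, so neither stands apart in this assay. Compound 3 `CCCCCCCCCC/N=C/N1CCC(C(c2ccccc2)c2ccccc2)CC1` has nonyl in place of vinyl on a saturated chain carbon bound to a double-bonded nitrogen. Going by the values given here, one measured step bears on this change, a 1.1-fold lower number from compound 1 to compound 2 (0.06 log units; within the scatter), and it stays within the scatter. Among the compounds with values here, no measured compound carries a nonyl chain, so the range is kept wide, but no step beyond the scatter is expected in this assay. The expected change is a 1.2-fold higher number from compound 2 to compound 3 (0.08 log units; within the scatter). Compound 3 is estimated at 16 mg/kg, with an expected range of 7 mg/kg to 40 mg/kg.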

Compound 3, dose for half-maximal effect: 43.1 mg/kg
Estimate against measurement, compound 3: 2.7-fold (0.43 log units) below; the whole stated range lies below it.
By their numbers in this assay, from the lowest: compounds 2 and 1 (each within the scatter of the next); then compound 3.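

Nonyl in place of vinyl on a saturated chain carbon bound to a double-bonded nitrogen gives a 3.3-fold higher number from compound 2 to compound 3 (0.51 log units; beyond the scatter) in this assay and so shows that this position is not indifferent to the chain it carries. Butyl in place of hydrogen further out along the chain gives a 2.9-fold higher number from compound 1 to compound 3 (0.46 log units; beyond the scatter) as well, so compound 3 stands apart from both earlier compounds, which lie within the scatter of each other. Nothing shown here accounts for this rise.

The compounds shown leave open whether the number climbs steadily or only past a certain chain length. They also leave open how a chain ending in an amine or a carboxylic acid would behave at this position.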